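Removing the Isopropylcarbonyl Group from the Chain Amine

The source may report more compounds than this note shows. Statements on the series, on what has been measured and on what is new or still open speak of the compounds shown alone.

Compound 1, `CC(C)C(=O)NCCS(=O)(=O)NC(=O)c1ccc(Nc2nc(NC3(c4ccc(Cl)cc4)CC3)nc(OCC(F)(F)F)n2)cc1`, gives 84% in an ADME assay on microsomes from liver (Rattus norvegicus) for metabolic stability, with a stated time of 10 min (on this read-out higher numbers stand for a more stable compound and lower numbers for a less stable compound), which places it at the low end of the three numbers measured. Compound 2, `CCS(=O)(=O)NC(=O)c1ccc(Nc2nc(NC3(c4ccc(Cl)cc4)CC3)nc(OCC(F)(F)F)n2)cc1`, gives 85% in this assay, and compound 3, `O=C(NS(=O)(=O)CCNCc1ccccc1)c1ccc(Nc2nc(NC3(c4ccc(Cl)cc4)CC3)nc(OCC(F)(F)F)n2)cc1`, gives 100%. The step of a number 1 percentage points higher from compound 1 to compound 2 (within the scatter) is within the scatter, whereas a number 16 percentage points higher from compound 1 to compound 3 (beyond the scatter) and a number 15 percentage points higher from compound 2 to compound 3 (beyond the scatter) both lie beyond it.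

Compound 4, `NCCS(=O)(=O)NC(=O)c1ccc(Nc2nc(NC3(c4ccc(Cl)cc4)CC3)nc(OCC(F)(F)F)n2)cc1`, has not yet been measured. It differs from compound 1 in one place: hydrogen in place of isopropylcarbonyl on an amine nitrogen. Within the data shown here, two measured steps bear on this. In a number 1 percentage points higher from compound 1 to compound 2 (within the scatter) the whole (isopropylcarbonyl)amino group was replaced by hydrogen with no shift beyond the scatter, and in a number 16 percentage points higher from compound 1 to compound 3 (beyond the scatter) the same amine nitrogen carried benzyl instead of isopropylcarbonyl and the number rose modestly. Taking off the isopropylcarbonyl while keeping the amine sits between those two changes, and no measured step leaves a bare amine on the chain, so the expectation is cautious. Compound 4 is expected to sit at about the level of compound 1 or somewhat higher. The step of a number 4 percentage points higher from compound 1 to compound 4 (within the scatter) is expected to be small. The estimate for compound 4 in this assay is 88%, with a range from 74% to 99%.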

Compound 4, percent of the compound remaining: 100%
Beside the measured number, compound 4's estimate is 12 percentage points below it, and the stated range ends below it.
By their numbers in this assay, from the lowest: compounds 1 and 2 (each within the scatter of the next); then compounds 3 and 4 (each within the scatter of the next).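

On the amine nitrogen, taking off the isopropylcarbonyl alone gives a number 16 percentage points higher from compound 1 to compound 4 (beyond the scatter) in this assay, so the rise seen earlier with benzyl on that nitrogen does not depend on the benzyl, and the benzyl-to-hydrogen change gives no change at the digits printed from compound 3 to compound 4 (within the scatter). Set against the chain with no nitrogen at all, the free amine gives a number 15 percentage points higher from compound 2 to compound 4 (beyond the scatter), which shows that among these four compounds the two with a non-acylated amine on the chain stand together above compound 1 and compound 2, while the isopropylcarbonyl-capped nitrogen of compound 1 reads level with the chain that has no amine. Nothing given here explains this difference between the capped and uncapped nitrogen.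

On these data alone, whether a smaller acyl group such as acetyl on this nitrogen behaves like isopropylcarbonyl, or a methyl or dimethylamino version of the amine behaves like the free amine and the benzylamine, remains open. Also open, as far as these compounds go, is whether a longer chain between the sulfonyl sulfur and the amine, or a carboxylic acid in place of the amine, would keep the number at the level of compound 3 and compound 4.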